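Urea series, cytotoxicity read-out: compound 2 to compound 3

The source may hold more compounds than are shown below. What is called first, only, known or untested is meant among the compounds shown, and "the series" means these compounds.

Measured compounds:
compound 1 `COc1ccc(CN(C(=O)Nc2ccc(C)cc2)n2cnnc2)cc1OC`: > 50000 nM in a functional assay on MCF7 cells (Homo sapiens) for cytotoxicity, read by MTT assay, with a stated time of 48 h (on this read-out lower numbers stand for stronger inhibition and higher numbers for weaker inhibition), a limit of the assay
compound 2 `Cc1ccc(NC(=O)N(Cc2ccccn2)n2cnnc2)cc1`: 38900 nM in this assay

For the measured compounds named here, compound 2 holds the only number in this assay. For compound 1 the assay reports a limit only (the limit of > 50000 nM in this assay, at which 1 of the 2 values shown sits). Compound 3 `CC1CCC(NC(=O)N(Cc2ccccn2)n2cnnc2)CC1` differs from compound 2 by 4-methylcyclohexyl in place of 4-methylphenyl on an amide-type nitrogen. Going by the values given here, no measured pair covers this change, so no step of known size exists. In this assay the step is expected to stay within the scatter, with weak inhibition kept. Compound 3 is estimated at 40000 nM, between 15000 nM and 110000 nM. The expected step from compound 2 to compound 3 is a 1.0-fold higher number from compound 2 to compound 3 (0.01 log units; within the scatter).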

Compound 3, half-maximal inhibitory concentration: 34000 nM
Beside the measured number, compound 3's estimate is 1.2-fold (0.07 log units) above it; measured number inside the range.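

In this assay, 4-methylcyclohexyl in place of 4-methylphenyl on the amide-type nitrogen gives a 1.1-fold lower number from compound 2 to compound 3 (0.06 log units; within the scatter), so for this pair an aromatic ring at this position is not required for the weak inhibition, and the non-aromatic ring serves equally well. For the compounds shown here, this is the first step of known size at this position, and it rests on a single pair. Nothing given here accounts for the step.

Going by these compounds, how an amine or a carboxylic acid on the ring would read remains open. So does a longer chain in place of the ring, and whether any group here moves the number beyond the scatter.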